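A Formylfuran Gives Way to a Pyrazole

The source may hold more compounds than are shown below. What is called first, only, known or untested is meant among the compounds shown, and "the series" means these compounds.

Measured in a functional assay on MV4-11 cells (Homo sapiens) for inhibition, read by resazurin assay, with a stated time of 72 h; a lower number here means a stronger inhibitor of growth, a higher number a weaker inhibitor of growth:
- compound 1 `O=C1NCCC12CCN(c1c(Cl)cncc1-c1ccco1)CC2` gives 940 nM
- compound 2 `O=Cc1ccc(-c2cncc(Cl)c2N2CCC3(CCNC3=O)CC2)o1` gives 5190 nM
- compound 3 `O=Cc1cc(-c2cncc(Cl)c2N2CCC3(CCNC3=O)CC2)co1` gives 5150 nM

Compound 3 stands level with compound 2, within the scatter, and both show a higher number than compound 1. Compound 4 `O=C1NCCC12CCN(c1c(Cl)cncc1-c1cn[nH]c1)CC2` has 1H-pyrazol-4-yl in place of 5-formylfuran-3-yl on an aromatic carbon. Among the compounds with values here, two measured steps bear on this change, both modest: a 5.5-fold higher number from compound 1 to compound 2 (0.74 log units; beyond the scatter) and a 5.5-fold higher number from compound 1 to compound 3 (0.74 log units; beyond the scatter) in each case. Compound 4 carries no formyl, like compound 1 at 940 nM in this assay, so a lower number is expected. Within the data shown here, no 1H-pyrazol-4-yl compound has been measured, so this is uncertain. The expected change is a 3.4-fold lower number from compound 3 to compound 4 (0.54 log units; beyond the scatter) and would be modest. For compound 4 the estimate is 1500 nM with an expected range from 400 nM to 5000 nM overall.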

Compound 4, concentration for 50% growth inhibition: 8520 nM
For compound 4 the middle estimate is 5.7-fold (0.75 log units) below the measured one; measured number outside the range, above it.
By their numbers in this assay, from the lowest: compound 1; then compounds 3, 2 and 4 (each within the scatter of the next).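

In this assay the absence of a formyl does not by itself bring the number down: a 1.7-fold higher number from compound 3 to compound 4 (0.22 log units; within the scatter) and a 1.6-fold higher number from compound 2 to compound 4 (0.22 log units; within the scatter) both stay within the scatter, while a 9.1-fold higher number from compound 1 to compound 4 (0.96 log units; beyond the scatter) lies beyond it. At this position the 1H-pyrazol-4-yl group therefore sits level with both formylfurans, and only the furan-2-yl of compound 1 stands apart. No measurement here explains this difference between the two rings. Still open, from the compounds shown here alone, is whether a furan-2-yl carrying an amine or a carboxylic acid would stay near compound 1. A methyl on the pyrazole nitrogen is equally untested among the compounds shown.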